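The compounds below may be only part of what the source reports. "The series", "measured", "known", "first", "only" and "open" are said of these compounds alone.

Measured so far:
- compound 1 `O=C(c1cccc(Cl)c1)N1CCC(NS(=O)(=O)c2cc(S(=O)(=O)c3ccccc3)ccc2C(F)(F)F)CC1`: 300 nM
- compound 2 `CN(C)c1ccc(C(=O)N2CCC(NS(=O)(=O)c3cc(S(=O)(=O)c4ccccc4)ccc3C(F)(F)F)CC2)cn1`: 40 nM

Both numbers come from an assay on isolated protein for displacement of a labelled ligand from secreted frizzled-related protein 1 (Homo sapiens), read by fluorescence polarization, with a stated time of 30 min; a higher number here means a weaker inhibitor, a lower number a stronger inhibitor. Going by the values given here, compound 1 stands at the higher of the two numbers; the only neighbour, compound 2, sits at a 7.5-fold lower number from compound 1 to compound 2 (0.88 log units; beyond the scatter), a step made by swapping the aromatic group on the carbonyl carbon while the rest of the shared core is unchanged.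

The next compound, compound 3 `O=S(=O)(NC1CCN(S(=O)(=O)c2ccccc2)CC1)c1cc(S(=O)(=O)c2ccccc2)ccc1C(F)(F)F`, departs from compound 1 at the same amine nitrogen in the ring but in a different way: phenylsulfonyl in place of (3-chlorophenyl)carbonyl on an amine nitrogen in a ring. Here the carbonyl itself is exchanged for a sulfonyl, not merely the aromatic ring on it. Among the compounds with values here, no measured pair shows an amide-to-sulfonamide exchange anywhere, so the one step that bears on the place, a 7.5-fold lower number from compound 1 to compound 2 (0.88 log units; beyond the scatter), tells only that this position tolerates variation of a modest size, not the direction for this particular change. Given that, compound 3 is expected to stay close to compound 1 in this assay, with a wide range and no step expected beyond the scatter in either direction; the estimated step is a 1.3-fold higher number from compound 1 to compound 3 (0.12 log units; within the scatter). The estimate for compound 3 is 400 nM, between 100 nM and 1600 nM.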

Compound 3, half-maximal inhibitory concentration: 130 nM
Compound 3: middle estimate off by 3.1-fold (0.49 log units), on the high side, and the stated range covers the measured number.
By their numbers in this assay, from the lowest: compound 2; then compound 3; then compound 1.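

In this assay, the carbonyl on the amine nitrogen in a ring is not essential: the exchange for phenylsulfonyl gives a 2.3-fold lower number from compound 1 to compound 3 (0.36 log units; beyond the scatter), the first sign that a sulfonyl can stand at this place and that the number can fall with it. The exchange also removes the chlorine, so the step belongs to the whole group and cannot be assigned to the sulfonyl alone. Set against the other amide, the same group gives a 3.3-fold higher number from compound 2 to compound 3 (0.51 log units; beyond the scatter), so the linking group alone does not set the order at this place: one amide, compound 2, has the lowest number of the three, while the other, compound 1, has the highest, and nothing at hand explains either step.

Going by these compounds, what remains open is how much of each step comes from the linking group and how much from the aromatic ring, a question that phenylcarbonyl and (3-chlorophenyl)sulfonyl groups at this place could settle. On these data alone, it is also open whether a dimethylamino group on the ring of the phenylsulfonyl lowers the number as far as in compound 2.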